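Trimming the Alkyl Chain in a Triazolyl Chalcone Series

The source may report more compounds than this note shows. Statements on the series, on what has been measured and on what is new or still open speak of the compounds shown alone.

Compound 1 `CCCCCCCCCCn1cc(/C=C/C(=O)c2ccc(NC(=O)CN3CCC(Cc4ccccc4)CC3)cc2)nn1` was examined in a functional assay on MCF7 cells (Homo sapiens) for inhibition, read by MTT assay (a lower number here means a stronger inhibitor, a higher number a weaker inhibitor), where compound 1 gives 55200 nM. Compound 2 `CCCCCCCCCCn1cc(/C=C/C(=O)c2ccc(NC(=O)CBr)cc2)nn1` gives 9760 nM in this assay, and compound 3 `CCCCCCCCn1cc(/C=C/C(=O)c2ccc(NC(=O)CBr)cc2)nn1` gives 12900 nM. Compound 1 therefore stands highest of the three measured numbers, and the difference between its core and that of compound 2 is not broken down here. The change from compound 2 to compound 3 is hydrogen in place of ethyl on a saturated chain carbon, eight bonds along the chain from an aromatic nitrogen, and its effect on this assay was a 1.3-fold higher number from compound 2 to compound 3 (0.12 log units; within the scatter). Compound 4 `CCCCCCCCn1cc(/C=C/C(=O)c2ccc(NC(=O)CN3CCC(Cc4ccccc4)CC3)cc2)nn1` has not yet been measured. It differs from compound 1 by hydrogen in place of ethyl on a saturated chain carbon, eight bonds along the chain from an aromatic nitrogen, the same kind of change as that between compound 2 and compound 3, made at a place described in the same words. Since the earlier step stayed within the scatter, the expectation is that compound 1 and compound 4 will likewise lie close together, and compound 4 is estimated to give 70000 nM in this assay, with a plausible range from 30000 nM to 160000 nM, which corresponds to an expected step of a 1.3-fold higher number from compound 1 to compound 4 (0.10 log units; within the scatter).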

Compound 4, half-maximal inhibitory concentration: 52600 nM
The estimate for compound 4 lay 1.3-fold (0.12 log units) above the measured number, and the stated range covers the measured number.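

In this assay, hydrogen in place of ethyl on a saturated chain carbon, eight bonds along the chain from an aromatic nitrogen, gave a 1.0-fold lower number from compound 1 to compound 4 (0.02 log units; within the scatter) on the core of compound 1. Set beside the earlier step, the same change reads alike on the two cores: the same change on two cores in this assay, a 1.3-fold higher number (0.12 log units; within the scatter) from compound 2 to compound 3 and a 1.0-fold lower number (0.02 log units; within the scatter) from compound 1 to compound 4, 1.4-fold (0.14 log units) apart, within the scatter of two such steps. This shows that, on these two cores and in this one assay, trimming the chain by this amount leaves the number where it was, and that the result carried over from one core to the other; it does not show that the change would be equally silent on any other core in the series, nor does it show what the chain contributes as a whole.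

The compounds shown leave open how a much shorter chain, such as propyl or methyl, would read at this place. They also leave open whether a chain ending in an amine or a carboxylic acid would behave like the plain chains seen here.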